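Swapping a Methoxy for a Hydroxyl on the Amide Chain

The compounds below may be only part of what the source reports. "The series", "measured", "known", "first", "only" and "open" are said of these compounds alone.

Of the compounds shown here, three sharing one core have been measured in an assay on HEK293 cells for agonist activity at transient receptor potential cation channel subfamily M member 8 (Homo sapiens), read by fluorescence and calcium flux, with a stated time of 15 min; a higher number here means that more compound is needed for the effect, a lower number that less compound is needed. Compound 1 `Cc1ccc(OCC(=O)N(Cc2cccs2)C(C)C)cc1` gives 70 nM. Compound 2 `Cc1ccc(OCC(=O)N(C)Cc2cccs2)cc1` gives 400 nM, and compound 3 `COCCN(Cc1cccs1)C(=O)COc1ccc(C)cc1` gives 400 nM. Compound 3 thus stands level with compound 2, and together they hold the highest numbers of the three, while compound 1 sits clearly lower, as the step of a 5.7-fold higher number from compound 1 to compound 3 (0.76 log units; beyond the scatter) shows.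

The next compound, compound 4 `Cc1ccc(OCC(=O)N(CCCO)Cc2cccs2)cc1`, differs from compound 3 in one place: hydroxymethyl in place of methoxy on a saturated chain carbon, two bonds along the chain from an amide-type nitrogen. Within the data shown here, no measured step exchanges a methoxy for a hydroxyl, so the bearing of the known steps is indirect. The steps of a 5.7-fold higher number from compound 1 to compound 2 (0.76 log units; beyond the scatter) and a 5.7-fold higher number from compound 1 to compound 3 (0.76 log units; beyond the scatter) show that changing the group on the amide nitrogen can shift the number modestly, and the step of no change at the digits printed from compound 2 to compound 3 (within the scatter) shows that lengthening that group with a methoxymethyl left the number unchanged. Because of no change at the digits printed from compound 2 to compound 3 (within the scatter), and since the change to compound 4 only rearranges the same atoms within that group, a small shift is expected, most likely none beyond the scatter. Compound 4 is therefore estimated at 500 nM, within a range of 150 nM to 1600 nM. This expected step amounts to a 1.3-fold higher number from compound 3 to compound 4 (0.10 log units; within the scatter).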

Compound 4, half-maximal effective concentration: 3000 nM
Compound 4: the middle estimate sits 6.0-fold (0.78 log units) below what was measured, outside the stated range (above it).
By their numbers in this assay, from the lowest: compound 1; then compounds 2 and 3 (each within the scatter of the next); then compound 4.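

Compound 3 and compound 4 hold the same atoms, joined differently, yet the change at this place gives a 7.5-fold higher number from compound 3 to compound 4 (0.88 log units; beyond the scatter) in this assay; what sits on this chain therefore matters even when its heavy atoms stay the same, and the entering hydroxymethyl counts 1 hydrogen-bond donor where the leaving methoxy counts 0. The longer chain on the amide-type nitrogen is thus not neutral in every form: the methoxy-ended chain of compound 3 matched the methyl of compound 2, whereas the hydroxyl-ended one gives a 7.5-fold higher number from compound 2 to compound 4 (0.88 log units; beyond the scatter) and, with 3-hydroxypropyl in place of isopropyl, a 43-fold higher number from compound 1 to compound 4 (1.63 log units; beyond the scatter) as the largest step in the set. Among these compounds, nothing available explains why this swap moves the number so far.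

Still open, from the compounds shown here alone, is whether the rise belongs to the hydroxyl alone or to the hydroxyl at this distance along the chain, a question that a 2-hydroxyethyl or a 4-hydroxybutyl group on the same nitrogen would address. An amine or a carboxylic acid in place of the hydroxyl would show whether other groups at this place follow the hydroxyl or the methoxy.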